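Benzyl variation on the triazole and cell toxicity

This account rests on a few compounds, and the source may have more. Where it says the series, first, only, none or still open, it means among the compounds named here.

In an ADME assay on MT4 cells (Homo sapiens) for cytotoxicity, read by MTT assay, with a stated time of 5 days (on this read-out lower numbers stand for higher toxicity in this test and higher numbers for lower toxicity in this test), compound 1 `CCOC(=O)Cn1cc(CNC(=O)c2cnc(Nc3ccc(C#N)cc3)cc2Oc2c(C)cc(C)cc2C)nn1` gives 9530 nM. Compound 2 `Cc1cc(C)c(Oc2cc(Nc3ccc(C#N)cc3)ncc2C(=O)NCc2cn(Cc3ccc(F)cc3)nn2)c(C)c1` reaches only a limit in this assay, >= 153000 nM, so for compound 2 only a range is known (the limit of >= 153000 nM in this assay, at which 1 of the 2 values shown sits). Within the data shown here, the single measured step, an at least 16-fold higher number from compound 1 to compound 2 (1.20 log units; beyond the scatter), is large. Compound 3 `Cc1cc(C)c(Oc2cc(Nc3ccc(C#N)cc3)ncc2C(=O)NCc2cn(Cc3cccc(C#N)c3)nn2)c(C)c1` differs from compound 2 by 3-cyanophenyl in place of 4-fluorophenyl on a saturated chain carbon bound to an aromatic nitrogen. No measured step compares two benzyl groups with each other; the one step shown moves from an ethoxycarbonyl chain to a benzyl group. For compound 3 the expected step is an at least 1.2-fold lower number from compound 2 to compound 3 (0.10 log units; that floor lies within the scatter), within the scatter, with a limit again likely. Compound 3 is estimated at 120000 nM, between 30000 nM and 250000 nM.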

Compound 3, half-maximal cytotoxic concentration: >= 129000 nM
Compound 3 gave a limit, no number; the forecaster's own chance of this, stated with the estimate: 60%; at least 1.0-fold (0.03 log units) between middle value and limit.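

In this assay, a second aromatic group on the saturated chain carbon bound to an aromatic nitrogen also departs from ethoxycarbonyl, giving an at least 13-fold higher number from compound 1 to compound 3 (1.13 log units; beyond the scatter). The higher number is therefore not confined to 4-fluorophenyl: it holds for 3-cyanophenyl too, though compound 3 gives only a limit, >= 129000 nM. The step from compound 2 to compound 3 cannot be read.

Going by these compounds, how far 4-fluorobenzyl and 3-cyanobenzyl differ in this read-out stays open. Also open, on these data alone, is whether an amine or a carboxylic acid at this place would give a number near compound 1 or a limit.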